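Swapping Hydroxy for Amino in a Weakly Active Series

The compounds below may be only part of what the source reports. "The series", "measured", "known", "first", "only" and "open" are said of these compounds alone.

The study concerns an assay on isolated protein for inhibition of LIM domain kinase 1 (Homo sapiens), read by Kinase-Glo, with a stated time of 60 min; on this read-out higher numbers stand for weaker inhibition and lower numbers for stronger inhibition. Compound 1, `NC(=O)c1sc2ccccc2c1O`, sits at the edge of the measurable range: in this assay compound 1 gives > 100000 nM, which is a limit of the assay rather than a number, as noted in the limit of > 100000 nM in this assay, at which 1 of the 3 values shown sits. Two further compounds carry an amino group rather than a hydroxy and do return numbers. Compound 2, `NC(=O)c1sc2cccnc2c1N`, gives 92000 nM in this assay, and compound 3, `Cc1ccc(-c2cc(C(F)(F)F)c3c(N)c(C(N)=O)sc3n2)o1`, gives 41000 nM in this assay. For the measured compounds named here, no step between measured compounds that differ in a single place is available, so nothing in the measured set fixes the size of any one change on its own.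

Compound 4, `NC(=O)c1sc2ccccc2c1N`, is the next compound to be measured. It differs from compound 1 by amino in place of hydroxy on an aromatic carbon. Compound 2 with 92000 nM and compound 3 with 41000 nM both carry the amino group and both return numbers, so a number rather than a limit is expected for compound 4 as well, though only a modest one. The estimate for compound 4 in this assay is 80000 nM, with a range from 30000 nM to 200000 nM. The step this estimate means is an at least 1.2-fold lower number from compound 1 to compound 4 (0.09 log units; that floor lies within the scatter), a small gain that may not exceed the usual scatter.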

Compound 4, half-maximal inhibitory concentration: 33000 nM
The estimate for compound 4 lay 2.4-fold (0.38 log units) above the measured number; measured number inside the range.
By their numbers in this assay, from the lowest: compounds 4 and 3 (each within the scatter of the next); then compound 2. At a limit, above all of these: compound 1.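

For the compounds shown here, with compound 4, the change of hydroxy to amino on an aromatic carbon can be read on its own for the first time in this assay, since no earlier pair differed in a single place: the swap gives an at least 3.0-fold lower number from compound 1 to compound 4 (0.48 log units; beyond the scatter). The two groups match in heavy-atom count, in hydrogen-bond donors and acceptors and in net charge, so at this position, next to the ring atom that bears a carbamoyl group, a step beyond the scatter accompanies the exchange of oxygen for nitrogen on an otherwise unchanged core. The full size of the step cannot be given, because compound 1 stands at a limit of the assay and not at a number: the limit of > 100000 nM in this assay, at which 1 of the 4 values shown sits.

The compounds shown leave open whether a methylamino or a methoxy group at this position would hold, extend or lose the lower number seen with the amino group. They also leave open how much the neighbouring carbamoyl group contributes, which a nitrile or a carboxylic acid in its place on the core of compound 4 would begin to address.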